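The source may report more compounds than this note shows. Statements on the series, on what has been measured and on what is new or still open speak of the compounds shown alone.

Measured so far in a functional assay on NALM-6 cells (Homo sapiens) for cytotoxicity, read by luminescence and CellTiter-Glo, with a stated time of 3 days; a lower number here means a stronger inhibitor, a higher number a weaker inhibitor:
Compound 1 `O=C(Nc1ccc(OC(F)(F)F)cc1)c1cc(F)ccc1O` gives 1210 nM
Compound 2 `O=C(Nc1ccc(OC(F)(F)F)c(Cl)c1)c1cc(F)ccc1O` gives 1000 nM
Compound 3 `O=C(Nc1ccc(OC(F)(F)F)c(Cl)c1)c1cc(Cl)ccc1O` gives 1050 nM

Compound 2 does not stand apart from the other two compounds, as both steps that reach it remain within the scatter. Compound 4 `O=C(Nc1ccc(Br)c(Cl)c1)c1cc(F)ccc1O` has not yet been measured. Within the data shown here, its difference from compound 2 is bromo in place of trifluoromethoxy on an aromatic carbon, ortho to a chloro group and para to a large group bromo in place of trifluoromethoxy on an aromatic carbon and no measured step touches the trifluoromethoxy group. The available guidance is therefore indirect. Chloro in place of hydrogen on an aromatic carbon gave a 1.2-fold lower number from compound 1 to compound 2 (0.08 log units; within the scatter) and chloro in place of fluoro on an aromatic carbon gave a 1.1-fold higher number from compound 2 to compound 3 (0.02 log units; within the scatter) so neither exchange moved the number beyond the scatter. Among the measured compounds shown here, on that basis, no step beyond the scatter is expected in this assay in either direction, although the exchange has no measured counterpart and the range must stay wide. The expected change is a 1.1-fold higher number from compound 2 to compound 4 (0.04 log units; within the scatter) and it remains only an estimate. For compound 4 the estimated value is 1100 nM with an expected range from 450 nM to 2700 nM until the measurement is available.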

Compound 4, half-maximal inhibitory concentration: 1250 nM
Estimate against measurement, compound 4: 1.1-fold (0.06 log units) below, and the stated range covers the measured number.
By their numbers in this assay, from the lowest: compounds 2, 3, 1 and 4 (each within the scatter of the next).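

In this assay, among these compounds, the trifluoromethoxy group on the aromatic carbon ortho to a chloro group is exchanged for the first time, and bromo in its place gives a 1.3-fold higher number from compound 2 to compound 4 (0.10 log units; within the scatter). Among the compounds shown here, the earlier compounds all carried trifluoromethoxy at this place, so they could show only that the other exchanges left the number within the scatter; compound 4 shows that this place also tolerates the loss of a group of 5 heavy atoms, including its hydrogen-bond acceptor, in favour of a single bromine atom without a change beyond the scatter. No measurement shown here offers an explanation for this result, and the pair gives no basis for assigning it a cause.

As far as these compounds go, what an amine or a carboxylic acid at this place would do to the number remains open, since both groups that have stood there so far carry no hydrogen-bond donor and no net charge. No step among these four compounds goes beyond the scatter, so the compounds shown do not yet identify any change on the shared core that moves the number in this assay.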